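A few compounds are considered here, and "the series" means these few. Any claim that something is new, unique, unknown or untested is made for them only; others in the source may bear on it.

Measured in a functional assay on HT-29 cells (Homo sapiens) for antiproliferative activity, read by MTT assay, with a stated time of 72 h; a lower number here means a stronger inhibitor, a higher number a weaker inhibitor:

- Compound 1 `Nc1nc(N)c2cc(CSC(=S)N3CCN(c4ccccc4)CC3)ccc2n1` gives 2760 nM
- Compound 2 `Nc1nc(N)c2cc(CSC(=S)N3CCN(c4ccccc4Cl)CC3)ccc2n1` gives 3900 nM
- Compound 3 `Nc1nc(N)c2cc(CSC(=S)N3CCN(c4ccccc4F)CC3)ccc2n1` gives 5420 nM

Compound 3 cannot be told apart from the other two compounds. The measured steps to it are a 2.0-fold higher number from compound 1 to compound 3 (0.29 log units; within the scatter), for fluoro in place of hydrogen on an aromatic carbon, and a 1.4-fold higher number from compound 2 to compound 3 (0.14 log units; within the scatter), for fluoro in place of chloro.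

Compound 4 `Nc1nc(N)c2cc(CSC(=S)N3CCN(c4ccc([N+](=O)[O-])cc4)CC3)ccc2n1` keeps the shared core but has 4-nitrophenyl in place of 2-fluorophenyl on an amine nitrogen in a ring. The difference in full is 4-nitrophenyl in place of 2-fluorophenyl on an amine nitrogen in a ring.

The closest evidence comes from those two steps, together with a 1.4-fold higher number from compound 1 to compound 2 (0.15 log units; within the scatter), for chloro in place of hydrogen. All three are small swaps on the same aromatic ring, and none leaves the scatter. For the measured compounds named here, they are only a thin guide, since no measured compound carries 4-nitrophenyl. Going by these steps, no change beyond the scatter is expected in this assay, in either direction.

The expected step is a 1.4-fold lower number from compound 3 to compound 4 (0.15 log units; within the scatter).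

For compound 4 the estimated value is 3800 nM, with an expected range from 1500 nM to 9000 nM.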

Compound 4, half-maximal inhibitory concentration: 3320 nM
The estimate for compound 4 lay 1.1-fold (0.06 log units) above the measured number; the range from low to high includes it.
By their numbers in this assay, from the lowest: compounds 1, 4, 2 and 3 (each within the scatter of the next).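

Compounds 1 to 3 carry only hydrogen, chloro or fluoro on this aromatic ring, whereas 4-nitrophenyl brings in a larger group with hydrogen-bond acceptors, and even so the numbers in this assay do not separate: the steps are a 1.2-fold higher number from compound 1 to compound 4 (0.08 log units; within the scatter), a 1.2-fold lower number from compound 2 to compound 4 (0.07 log units; within the scatter) and a 1.6-fold lower number from compound 3 to compound 4 (0.21 log units; within the scatter). The step from compound 1 is the cleanest reading, since it only adds nitro to the unsubstituted ring, and it shows that this addition leaves the number within the scatter, just as chloro and fluoro did. The steps from compound 2 and compound 3 swap one substituted ring for another, and they too show that the four compounds form a single group with no order among them, although nothing available explains this flat result.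

On these data alone, it remains open whether any group on this ring can move the number beyond the scatter, such as an amine or a carboxylic acid. Also open, as far as these compounds go, is what would happen if the whole aromatic ring on the amine nitrogen gave way to something quite different, such as a methyl group or a longer chain.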